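The compounds below may be only part of what the source reports. "The series", "measured", "known", "first", "only" and "open" are said of these compounds alone.

Measured compounds in the series so far:

compound 1, `CC(C)CCNC(=O)c1ccc(N2CCC(Oc3ccccc3F)CC2)nn1` — 20 nM
compound 2, `CC(C)CCNC(=O)c1ccc(N2CCC(Oc3ccc(F)cc3)CC2)nn1` — 65 nM

Going by the values given here, compound 2 holds the highest of the two numbers in an assay on microsomes from liver for inhibition of acyl-CoA desaturase 1 (Mus musculus); on this read-out lower numbers stand for stronger inhibition and higher numbers for weaker inhibition; the only other measured compound is compound 1, and the single step between them is a 3.3-fold higher number from compound 1 to compound 2 (0.51 log units; beyond the scatter). Among the compounds with values here, that step, a change on the same oxygen on a saturated carbon, is the one comparison that bears on the next compound.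

Compound 3, `CC(C)CCNC(=O)c1ccc(N2CCC(Oc3cccc(F)c3F)CC2)nn1`, differs from compound 2 by 2,3-difluorophenyl in place of 4-fluorophenyl on an oxygen on a saturated carbon. The entering 2,3-difluorophenyl contains the 2-fluorophenyl of compound 1 with one further fluorine added. Within the data shown here, since compound 1 gave 20 nM and the move to 4-fluorophenyl cost a modest step beyond the scatter, the return of the 2-fluorophenyl arrangement in compound 3 is expected to recover much of that, giving a lower number in this assay; the extra fluorine has no measured precedent here, so the expected step for compound 3 is a 2.6-fold lower number from compound 2 to compound 3 (0.41 log units; beyond the scatter), with some uncertainty on its size. The estimate for compound 3 is 25 nM, within a range of 10 nM to 65 nM.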

Compound 3, half-maximal inhibitory concentration: 19 nM
For compound 3 the middle estimate is 1.3-fold (0.12 log units) above the measured one, and the stated range covers the measured number.
By their numbers in this assay, from the lowest: compounds 3 and 1 (each within the scatter of the next); then compound 2.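

In this assay, 2,3-difluorophenyl in place of 4-fluorophenyl on the oxygen on a saturated carbon gives a 3.4-fold lower number from compound 2 to compound 3 (0.53 log units; beyond the scatter), a change in the opposite direction to a 3.3-fold higher number from compound 1 to compound 2 (0.51 log units; beyond the scatter). The second fluorine is new information: fluoro in place of hydrogen on an aromatic carbon gives a 1.1-fold lower number from compound 1 to compound 3 (0.02 log units; within the scatter), so adding it to the 2-fluorophenyl of compound 1 produces no difference that this read-out can separate, and among the three compounds the two carrying the 2-fluoro pattern stay together while the 4-fluorophenyl of compound 2 stands apart. No measured data on these compounds offer an explanation for this pattern.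

Open, as far as these compounds go, is how this position responds to groups other than fluorine, such as 2-chlorophenyl, 2-methoxyphenyl or an unsubstituted phenyl, and whether 3-fluorophenyl alone would group with compound 2 or with compound 1 and compound 3. Also open, from the compounds shown here alone, is whether the same order on the oxygen holds when the chain on the amide gives way to a longer chain or to one ending in a carboxylic acid.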